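The compounds below may be only part of what the source reports. "The series", "measured", "known", "first", "only" and "open" are said of these compounds alone.

Compound 1, `CCCCCCOc1ccc(-n2cnnc2CCCC)cc1`: 13.6 mg/kg in a functional assay on the whole organism (strain C57B/6) with Mus musculus as the target, in the maximal electroshock model; on this read-out higher numbers stand for an effect only at larger amounts of compound and lower numbers for an effect already at smaller amounts.
Compound 2, `CCCCCCCc1nncn1-c1ccc(OCCCCCC)cc1`: in this assay compound 2 gives only a limit of the assay, > 40 mg/kg.
Compound 3, `CCCCCCOc1ccc(-n2cnnc2-c2ccccc2F)cc1`: 20.2 mg/kg in this assay.

All three share one core and differ only in the group carried on one aromatic carbon of that core. Compound 3 and compound 1 sit close together in this assay, since a 1.5-fold higher number from compound 1 to compound 3 (0.17 log units; within the scatter). For compound 2 only a limit was recorded (the limit of > 40 mg/kg in this assay, at which 1 of the 3 values shown sits), and from it to compound 3 the change reads an at least 1.9-fold lower number from compound 2 to compound 3 (0.29 log units; that floor lies within the scatter), a floor that also lies within the scatter.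

The unmeasured compound 4, `CCCCCCOc1ccc(-n2cnnc2-c2ccccc2Cl)cc1`, follows from compound 3 by a single small exchange: chloro in place of fluoro on an aromatic carbon. Going by the values given here, no measured step swaps one halogen for another. The steps that touch the same aromatic carbon, a 1.5-fold higher number from compound 1 to compound 3 (0.17 log units; within the scatter) and an at least 1.9-fold lower number from compound 2 to compound 3 (0.29 log units; that floor lies within the scatter), exchanged much larger groups and still stayed within the scatter, so a change as small as fluoro to chloro is expected to move this assay by no more than that scatter. The expected step is therefore a 1.0-fold lower number from compound 3 to compound 4 (0.00 log units; within the scatter), in no firm direction. For compound 4 the estimate in this assay is 20 mg/kg, with a range from 10 mg/kg to 40 mg/kg.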

Compound 4, dose for half-maximal effect: 13.2 mg/kg
Compound 4: middle estimate off by 1.5-fold (0.18 log units), on the high side; measured number inside the range.
By their numbers in this assay, from the lowest: compounds 4, 1 and 3 (each within the scatter of the next). At a limit, above all of these: compound 2.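

In this assay, going by these compounds alone, the exchange of 2-fluorophenyl for 2-chlorophenyl gives a 1.5-fold lower number from compound 3 to compound 4 (0.18 log units; within the scatter), a direct comparison of two halogens that the earlier compounds lacked, and on this evidence the two cannot be told apart. Butyl and 2-chlorophenyl on the same aromatic carbon cannot be told apart either, with a 1.0-fold lower number from compound 1 to compound 4 (0.01 log units; within the scatter), so a flexible chain and a halogen-bearing aromatic ring fit equally well with this read-out here. The exchange against heptyl now clears the scatter, with an at least 3.0-fold lower number from compound 2 to compound 4 (0.48 log units; beyond the scatter), which the same exchange with 2-fluorophenyl did not do, yet the number for compound 2 is only a limit: the limit of > 40 mg/kg in this assay, at which 1 of the 4 values shown sits.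

The compounds shown leave open whether a larger group ortho to a large group, such as bromo or methoxy, or an unsubstituted phenyl ring, would stay with these values or separate from them. They also leave open where between butyl and heptyl the number starts to climb, a question that a pentyl or hexyl chain on the same aromatic carbon could answer.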